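The source may report more compounds than this note shows. Statements on the series, on what has been measured and on what is new or still open speak of the compounds shown alone.

In a functional assay (aorta) with Rattus norvegicus as the target, in the presence of a further agent that is not named here (on this read-out higher numbers stand for an effect only at larger amounts of compound and lower numbers for an effect already at smaller amounts), compound 1 `COC(=O)C1=C(C)N=C(C)/C(=C(\O)OC)C1c1cccc([N+](=O)[O-])c1` gives 3.4 nM. Compound 2 `COC(=O)C1=C(C)N=C(C)/C(=C(/O)OC)C1c1cccc(OCc2no[n+]([O-])c2C)c1` stands far higher at 500 nM, and compound 3 `COC(=O)C1=C(C)N=C(C)/C(=C(/O)OC)C1c1ccccc1OCc1c(C(N)=O)no[n+]1[O-]` lies within the scatter of it at 560 nM. Compound 4 `COC(=O)C1=C(C)N=C(C)/C(=C(/O)OC)C1c1cccc(OCc2c(C#N)no[n+]2[O-])c1` differs from compound 2 by a group of 8 heavy atoms (3 carbon, 3 nitrogen, 2 oxygen; one five-membered aromatic ring with 3 hetero atoms) in place of a group of 7 heavy atoms (3 carbon, 2 nitrogen, 2 oxygen; one five-membered aromatic ring with 3 hetero atoms), on a saturated chain carbon bound to an oxygen on an aromatic ring, and the entering group holds a triple bond outside aromatic rings. For the measured compounds named here, no measured step isolates this change in this assay. Going by the values given here, the only guide is that compound 2 at 500 nM and compound 3 at 560 nM sit together although their groups differ, so no step beyond the scatter is expected. The expected step is a 1.4-fold lower number from compound 2 to compound 4 (0.15 log units; within the scatter). Compound 4 is estimated at 350 nM, with an expected range from 90 nM to 1300 nM.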

Compound 4, half-maximal effective concentration: 11 nM
For compound 4 the middle estimate is 32-fold (1.50 log units) above the measured one; the measured number lies below the stated range.
By their numbers in this assay, from the lowest: compound 1; then compound 4; then compounds 2 and 3 (each within the scatter of the next).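

In this assay the exchange on a saturated chain carbon bound to an oxygen on an aromatic ring gives a 45-fold lower number from compound 2 to compound 4 (1.66 log units; beyond the scatter) and thus a step beyond the scatter. This place is therefore not indifferent to which five-membered aromatic ring with 3 hetero atoms it carries, and the entering group is the one holding a nitrile. No measurement shown here accounts for this step.

As far as these compounds go, whether the nitrile alone carries the step stays open. Also open, from the compounds shown here alone, is what a carboxylic acid or an amine would give in its place on this ring.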